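The source may report more compounds than this note shows. Statements on the series, on what has been measured and on what is new or still open speak of the compounds shown alone.

Compound 2 `N#Cc1cc(F)ccc1C1CCN(CCCNC(=O)C2=CNC(=O)N[C@@H]2c2ccc(F)c(F)c2)CC1` gives 62 nM in an in vitro assay on HEK293 cells with Alpha-1D adrenergic receptor (Homo sapiens) as the target (on this read-out lower numbers stand for stronger inhibition and higher numbers for weaker inhibition), while compound 1 `O=C1NC=C(C(=O)NCCCN2CCC(c3ccc(F)cc3)CC2)[C@@H](c2ccc(F)c(F)c2)N1` gives 68 nM in this assay, and the two lie within the usual scatter of each other. For the measured compounds named here, the single measured step, a 1.1-fold lower number from compound 1 to compound 2 (0.04 log units; within the scatter), concerns a cyano group on an aromatic carbon and does not bear on the change leading to compound 3 `CN1C=C(C(=O)NCCCN2CCC(c3ccc(F)cc3C#N)CC2)[C@@H](c2ccc(F)c(F)c2)NC1=O`, which is methyl in place of hydrogen on an amide-type nitrogen in a ring. Going by the values given here, no measured step speaks to this change, so the expectation rests on compound 2 and its value of 62 nM. For compound 3 a step of a 1.8-fold higher number from compound 2 to compound 3 (0.25 log units; within the scatter) is expected. Compound 3 is estimated at 110 nM, with a range from 30 nM to 400 nM.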

Compound 3, inhibition constant: 69 nM
Compound 3: the middle estimate sits 1.6-fold (0.20 log units) above what was measured; the range from low to high includes it.
By their numbers in this assay, from the lowest: compounds 2, 1 and 3 (each within the scatter of the next).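

In this assay, methyl in place of hydrogen on the amide-type nitrogen in the ring gives a 1.1-fold higher number from compound 2 to compound 3 (0.05 log units; within the scatter). For the compounds shown here, this is the first reading at this position: in compound 3 the hydrogen on that nitrogen can be replaced by methyl without a step beyond the scatter, which the earlier cyano step could not show. Nothing at hand explains this result.

The compounds shown leave open whether an ethyl group, a longer chain or a chain ending in an amine would be tolerated on this nitrogen. They also leave open whether methyl there would read the same without the cyano group.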